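Chain extension on the core of compound 2

A few compounds are considered here, and "the series" means these few. Any claim that something is new, unique, unknown or untested is made for them only; others in the source may bear on it.

Compound 2 `CCc1ncnc(NC(CC)c2ccc(Oc3ccc(F)cc3)cc2)c1Br` in an ADME assay on HEK-293T cells (Homo sapiens) for cytotoxicity, with a stated time of 48 h (a higher number here means that more compound is tolerated, a lower number that less compound is tolerated), reports only a limit, > 10000 nM. Compound 1 `CCCc1cc(NC(CC)c2ccc(Oc3ccc(F)cc3)cc2)ncn1` likewise reaches only a limit in this assay, > 10000 nM. The step that the two limits leave unreadable from compound 1 to compound 2 therefore cannot be read, since both values sit at the same limit (the limit of > 10000 nM in this assay, at which 2 of the 2 values shown sit). Compound 3 `CCCc1ncnc(NC(CC)c2ccc(Oc3ccc(F)cc3)cc2)c1Br` differs from compound 2 by methyl in place of hydrogen on a saturated chain carbon, two bonds along the chain from an aromatic carbon. Among the measured compounds shown here, no measured step bears on this change; the single step available is unreadable. With both measured compounds at the limit, a step of no readable size is expected for a step that the limit leaves unreadable from compound 2 to compound 3, and compound 3 is expected to sit at the limit as well. Compound 3 is estimated at 15000 nM, within 7000 nM to 40000 nM, most probably reported once more as a limit.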

Compound 3, half-maximal cytotoxic concentration: > 10000 nM
Compound 3 ended at the assay's limit; the forecaster's own chance of this, stated with the estimate: 85%; the middle value lies beyond the limit too.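

No step can be read among compound 1, compound 2 and compound 3 in this assay, as all three values are limits: the limit of > 10000 nM in this assay, at which 3 of the 3 values shown sit.

As far as these compounds go, how far each compound lies beyond this limit, and whether the methyl or bromo change alters tolerance at all, stays open.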